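Two Chlorines on the Ring at the Sulfonyl Sulfur

The source may hold more compounds than are shown below. What is called first, only, known or untested is meant among the compounds shown, and "the series" means these compounds.

In an assay on isolated protein for displacement of a labelled ligand from metabotropic glutamate receptor 5 (Homo sapiens), with a stated time of 60 min, tested at 1 uM (a higher number here means more inhibition at the concentration tested (going by the name of the read-out), a lower number less inhibition), compound 3 `CC1CCN(c2c(S(=O)(=O)c3ccccc3)cnc3cc(F)ccc23)CC1` gives 87%, the second highest of three numbers. Its nearest neighbour is compound 2 `COc1ccc(S(=O)(=O)c2cnc3cc(F)ccc3c2N2CCC(C)CC2)cc1` with 90%, and compound 1 `Cc1cc(C)cc(S(=O)(=O)c2cnc3cc(F)ccc3c2N2CCC(C)CC2)c1` gives 80%; the steps of a number 3 percentage points lower from compound 2 to compound 3 (within the scatter) and a number 7 percentage points higher from compound 1 to compound 3 (within the scatter) both stay within the scatter. Compound 4 `CC1CCN(c2c(S(=O)(=O)c3cc(Cl)cc(Cl)c3)cnc3cc(F)ccc23)CC1` differs from compound 3 in one place: 3,5-dichlorophenyl in place of phenyl on a sulfonyl sulfur. Going by the values given here, the steps that bear on this change are a number 7 percentage points higher from compound 1 to compound 3 (within the scatter) and a number 10 percentage points higher from compound 1 to compound 2 (within the scatter), both within the scatter, so exchanging groups on the ring attached to the sulfonyl sulfur has not moved the inhibition beyond the scatter. Among the compounds with values here, no measured step covers chlorine, but on this evidence the step of a number 2 percentage points lower from compound 3 to compound 4 (within the scatter) is expected to stay within the scatter. The estimate for compound 4 is 85%, with a range from 68% to 96%.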

Compound 4, a percentage reported as inhibition, at one concentration (the size of the read-out at that concentration, not a potency): 87%
Compound 4: the middle estimate sits 2 percentage points below what was measured; measured number inside the range.
By their numbers in this assay, from the lowest: compounds 1, 3, 4 and 2 (each within the scatter of the next).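

In this assay, two chlorines on the ring at the sulfonyl sulfur leave the number where it was: no change at the digits printed from compound 3 to compound 4 (within the scatter), while a number 3 percentage points lower from compound 2 to compound 4 (within the scatter) and a number 7 percentage points higher from compound 1 to compound 4 (within the scatter). The earlier compounds shown here carried only methyl or methoxy groups on this ring, so chlorine now joins them without a change beyond the scatter. No measurement here offers an explanation for this. Still open, on these data alone, is whether an amine or a carboxylic acid on this ring would keep the inhibition. A single test concentration also cannot separate these compounds by potency.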